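A few compounds are considered here, and "the series" means these few. Any claim that something is new, unique, unknown or untested is made for them only; others in the source may bear on it.

Compound 1 `CC(=O)Oc1ccccc1C(=O)O[C@H]1CO[C@H]2[C@@H]1OC[C@H]2OC(=O)C1CC1` and compound 2 `COc1cccc(C(=O)O[C@@H]2CO[C@H]3[C@@H]2OC[C@@H]3OC(=O)c2ccccc2OC(C)=O)c1` share a core that carries two ester groups and differ only in the acyl group on one of them. Both were studied in an ADME assay on a cell-free system (plasma, Homo sapiens) for metabolic stability, with Plasma (Rattus norvegicus) as the target, read by HPLC, at pH 7.4; a lower number here means that the compound disappears faster, a higher number that the compound lasts longer. In this assay compound 1 gives 0.015 h, which is the higher of the two numbers measured, while compound 2 gives 0.0142 h. Going by the values given here, the single measured step, a 1.1-fold lower number from compound 1 to compound 2 (0.02 log units; within the scatter), arose from placing 3-methoxyphenyl in place of cyclopropyl on a carbonyl carbon and did not move the half-life beyond the scatter.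

Compound 3 `CC(=O)Oc1ccccc1C(=O)O[C@H]1CO[C@H]2[C@@H]1OC[C@H]2OC(=O)c1cnoc1C` is the next member of the pair. It differs from compound 1 as follows: 5-methyl-1,2-oxazol-4-yl in place of cyclopropyl on a carbonyl carbon. Among the compounds with values here, this exchange of the cyclopropyl acyl group for an aromatic five-membered ring resembles the one measured step, which exchanged the same cyclopropyl for an aromatic six-membered ring and left the half-life essentially unchanged. The same outcome is therefore expected here: the step of no change at the digits printed from compound 1 to compound 3 (within the scatter) is estimated to stay within the scatter, with no direction favoured. The half-life of compound 3 in this assay is accordingly estimated at 0.015 h. For compound 3 the expected range runs from 0.0075 h to 0.03 h.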

Compound 3, half-life: 0.001 h
Compound 3: the middle estimate sits 15-fold (1.18 log units) above what was measured; measured number outside the range, below it.
By their numbers in this assay, from the lowest: compound 3; then compounds 2 and 1 (each within the scatter of the next).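

At this acyl position the half-life in this assay does depend on the group, which the earlier pair had not shown: 5-methyl-1,2-oxazol-4-yl on the carbonyl carbon gives a 15-fold lower number from compound 1 to compound 3 (1.18 log units; beyond the scatter) and, measured against the aromatic 3-methoxyphenyl group, gives a 14-fold lower number from compound 2 to compound 3 (1.15 log units; beyond the scatter) as well. Cyclopropyl and 3-methoxyphenyl remain within the scatter of each other, so an aromatic ring in this place does not by itself shorten the half-life, and compound 2 goes against any such reading. Nothing at hand accounts for the gap between the 5-methyl-1,2-oxazol-4-yl group and the other two acyl groups.

The compounds shown leave open which of the two ester groups is lost first and whether the short half-life of compound 3 belongs to the ring as a whole or to its methyl group. They also leave open how a pyridine ring, an unsubstituted 1,2-oxazol-4-yl ring or a longer alkyl chain on the same carbonyl carbon would read in this assay.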